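Swapping a Triazole for a Carboxylic Acid

The compounds below may be only part of what the source reports. "The series", "measured", "known", "first", "only" and "open" are said of these compounds alone.

Three measured compounds share one core and differ only in a single group on the outer benzene ring. Compound 1 `COc1ccc(-c2cc(-c3ccc(S(=O)(=O)NC4CC4)cc3)cnc2N)cn1` carries a cyclopropylsulfamoyl group, and in a physicochemical assay for lipophilicity, at pH 7.4 (a lower number here means a more polar compound, a higher number a more lipophilic compound), compound 1 gives 2.7. Compound 2 `COc1ccc(-c2cc(-c3ccc(NS(C)(=O)=O)cc3)cnc2N)cn1` carries a methanesulfonamido group, and compound 2 gives 2.2. Compound 3 `COc1ccc(-c2cc(-c3ccc(-n4cncn4)cc3)cnc2N)cn1` carries a 1H-1,2,4-triazol-1-yl group, and compound 3 gives 2.4. Compound 3 sits between the other two, yet both of its gaps lie within the scatter: a number 0.30 log units lower from compound 1 to compound 3 (within the scatter) and a number 0.20 log units higher from compound 2 to compound 3 (within the scatter). Among the measured compounds shown here, the only step beyond the scatter is a number 0.50 log units lower from compound 1 to compound 2 (beyond the scatter).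

Compound 4 `COc1ccc(-c2cc(-c3ccc(C(=O)O)cc3)cnc2N)cn1` is not yet measured. Its change from compound 3 is carboxy in place of 1H-1,2,4-triazol-1-yl on an aromatic carbon. For the measured compounds named here, no measured step brings in a carboxy, so the earlier steps set no close precedent, and the two steps that touch the triazole were small. With a carboxy entering in place of the triazolyl, the step of a number 2.00 log units lower from compound 3 to compound 4 (beyond the scatter) is nevertheless expected to be large and downward. Compound 4 is therefore estimated at 0.4, with a range from -0.6 to 1.4.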

Compound 4, distribution coefficient: 0.8
Estimate against measurement, compound 4: 0.40 log units below, and the stated range covers the measured number.
By their numbers in this assay, from the lowest: compound 4; then compounds 2, 3 and 1 (each within the scatter of the next, the first and the last beyond it).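

Among the earlier compounds, the widest step at this aromatic carbon was a number 0.50 log units lower from compound 1 to compound 2 (beyond the scatter) and so they gave no sign of how far this assay could move with a change of group here. Carboxy moves it much further, with a number 1.60 log units lower from compound 3 to compound 4 (beyond the scatter) and a number 1.40 log units lower from compound 2 to compound 4 (beyond the scatter) and finally a number 1.90 log units lower from compound 1 to compound 4 (beyond the scatter) as all three steps run the same way and leave compound 4 with the lowest number of the four. Nothing measured here explains the size of these steps.

On these data alone, it remains open whether the drop belongs to the carboxy alone or would also come with a methyl ester or a primary amide on the same aromatic carbon. As far as these compounds go, it is equally open whether a carboxymethyl group, with its longer chain, would give a step of similar size.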